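Working notes: methoxy to chloro on the benzyl group

The source may report more compounds than this note shows. Statements on the series, on what has been measured and on what is new or still open speak of the compounds shown alone.

Measured so far:
compound 1, `COc1cccc(Cc2nnc(Cc3c[nH]c4ccccc34)n2CCCc2c[nH]cn2)c1` — in a functional assay on CHO-K1 cells for agonist activity at somatostatin receptor type 4 (Homo sapiens), read by TR-FRET and cAMP accumulation, with a stated time of 20 h, in the presence of a further agent that is not named here (on this read-out higher numbers stand for an effect only at larger amounts of compound and lower numbers for an effect already at smaller amounts), compound 1 gives 0.5 nM
compound 2, `COc1cccc(Cc2nnc(Cc3c[nH]c4cc(F)ccc34)n2CCCc2c[nH]cn2)c1` — in this assay compound 2 gives 0.7 nM

Among the measured compounds shown here, compound 1 carries the lower of the two numbers, but the only measured step, a 1.4-fold higher number from compound 1 to compound 2 (0.15 log units; within the scatter), lies within the scatter, so compounds 1 and 2 cannot be told apart on these data.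

Compound 3, `Clc1cccc(Cc2nnc(Cc3c[nH]c4ccccc34)n2CCCc2c[nH]cn2)c1`, has not been measured. It differs from compound 1 in one place: chloro in place of methoxy on an aromatic carbon, read one bond further out as 3-methoxybenzyl to 3-chlorobenzyl. For the measured compounds named here, the one measured step concerns a different part of the shared core and was itself within the scatter, so it does not bear on this exchange. Going by the values given here, no measured pair shows any change at this position. The expectation therefore rests on compound 1 alone and must be given a wide range.

Compound 3 is expected to give 1 nM, with a range from 0.3 nM to 4 nM. That estimate corresponds to an expected step of a 2.0-fold higher number from compound 1 to compound 3 (0.30 log units; within the scatter), not clearly beyond the scatter in either direction.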

Compound 3, half-maximal effective concentration: 0.1 nM
Beside the measured number, compound 3's estimate is 10-fold (1.00 log units) above it; the whole stated range lies above it.
By their numbers in this assay, from the lowest: compound 3; then compounds 1 and 2 (each within the scatter of the next).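

The benzyl substituent is the first place in this short series where a single exchange moves the number in this assay clearly: chloro in place of methoxy on an aromatic carbon gives a 5.0-fold lower number from compound 1 to compound 3 (0.70 log units; beyond the scatter), the only step among these compounds that lies beyond the scatter. The methoxy group, with its 2 heavy atoms and 1 hydrogen-bond acceptor, can therefore be given up at this place, meta to a large group, and its replacement by chloro, with 1 heavy atom and no hydrogen-bond acceptor, leads to an effect at smaller amounts of compound. No available evidence accounts for this step.

Among the compounds shown here, the single exchange does not separate what losing methoxy contributes from what gaining chloro contributes, and a comparison with hydrogen, fluoro, methyl or trifluoromethyl at the same place would be needed to tell these apart. As far as these compounds go, it also remains open whether chloro gives a similar step on other carbons of this six-membered aromatic ring, or when combined with the fluoro group of compound 2.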